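Methoxy added ortho to a thioether chain

A few compounds are considered here, and "the series" means these few. Any claim that something is new, unique, unknown or untested is made for them only; others in the source may bear on it.

Measured so far:
compound 1 `COc1ccc(OC(C)CNC(C)=O)cc1`: 42700 nM
compound 2 `CC(=O)NCC(C)Oc1ccccc1`: 1380 nM
compound 3 `CC(=O)NCCSc1ccccc1`: 3800 nM

All three were tested in an assay on NIH3T3 cells for displacement of a labelled ligand from melatonin receptor type 1A (Homo sapiens), with a stated time of 90 min; on this read-out higher numbers stand for weaker inhibition and lower numbers for stronger inhibition. Compound 2 and compound 1 differ by one change, (methoxy in place of hydrogen on an aromatic carbon), and the step was a 31-fold higher number from compound 2 to compound 1 (1.49 log units; beyond the scatter). The difference between the cores of compound 2 and compound 3 is not broken down here. Compound 4 `COc1ccccc1SCCNC(C)=O` carries the same kind of change on the core of compound 3, (methoxy in place of hydrogen on an aromatic carbon), but the place differs: in compound 1 the methoxy is para to a group of 8 heavy atoms, in compound 4 it is ortho to a group of 7 heavy atoms. Because compound 1 gave 42700 nM after that step, a weakening is expected here too, estimated as a 3.9-fold higher number from compound 3 to compound 4 (0.60 log units; beyond the scatter), giving an expected value for compound 4 of 15000 nM (estimated between 3000 nM and 60000 nM).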

Compound 4, inhibition constant: 3630 nM
The estimate for compound 4 lay 4.1-fold (0.62 log units) above the measured number; low and high end bracket the measured number.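

In this assay, methoxy in place of hydrogen gave a 1.0-fold lower number from compound 3 to compound 4 (0.02 log units; within the scatter), so the large weakening seen on the other core did not recur. Among the compounds shown here, this change therefore does not carry over as a fixed step between these two cores: the same change on two cores in this assay, a 31-fold higher number (1.49 log units; beyond the scatter) from compound 2 to compound 1 and a 1.0-fold lower number (0.02 log units; within the scatter) from compound 3 to compound 4, 32-fold (1.51 log units) apart, beyond the scatter of two such steps What this does not show is which difference matters, since the cores differ and the methoxy in compound 4, ortho to a group of 7 heavy atoms, also sits in a different place from the one in compound 1.

From the compounds shown here alone, it remains open how methoxy would behave if its place were swapped between the two cores. Going by these compounds, it is also open whether a hydroxyl or an ethoxy in the place it holds in compound 4 would match methoxy.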